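Linker extension: compound 2 to compound 3

The source may hold more compounds than are shown below. What is called first, only, known or untested is meant among the compounds shown, and "the series" means these compounds.

Measured so far:
compound 1 `COc1cc2c(Nc3ccc(F)c(Cl)c3)ncnc2cc1OCCCn1ccnc1[N+](=O)[O-]` — 4310 nM
compound 2 `COc1cc2c(Nc3cccc(Br)c3)ncnc2cc1OCCCn1ccnc1[N+](=O)[O-]` — 7830 nM

In a functional assay on A549 cells (Homo sapiens) for inhibition, read by sulforhodamine B assay, with a stated time of 72 h (a lower number here means a stronger inhibitor, a higher number a weaker inhibitor), compound 1 gives 4310 nM and compound 2 gives 7830 nM. Going by the values given here, the only measured step, a 1.8-fold higher number from compound 1 to compound 2 (0.26 log units; within the scatter), changes the group on the nitrogen on an aromatic ring and lies within the scatter, so compound 2 stands together with compound 1 rather than apart from it.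

Compound 3 `COc1cc2c(Nc3cccc(Br)c3)ncnc2cc1OCCOCCn1ccnc1[N+](=O)[O-]` keeps the 3-bromophenyl of compound 2 and differs only in the chain: 2-(2-nitro-1H-imidazol-1-yl)ethoxy in place of (2-nitro-1H-imidazol-1-yl)methyl on a saturated chain carbon, two bonds along the chain from an oxygen on an aromatic ring. Among the compounds with values here, no measured step touches this chain, so nothing among the measured compounds bears directly on it; the one step measured, a 1.8-fold higher number from compound 1 to compound 2 (0.26 log units; within the scatter), concerns a different part of the molecule. Within the data shown here, with no relevant precedent, the expected step of a 1.0-fold lower number from compound 2 to compound 3 (0.00 log units; within the scatter) is none beyond the scatter, in either direction. Compound 3 is therefore estimated at 7800 nM, with an expected range of 3000 nM to 20000 nM.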

Compound 3, half-maximal inhibitory concentration: 10100 nM
Estimate against measurement, compound 3: 1.3-fold (0.11 log units) below; the range from low to high includes it.
By their numbers in this assay, from the lowest: compounds 1, 2 and 3 (each within the scatter of the next, the first and the last beyond it).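

In this assay, 2-(2-nitro-1H-imidazol-1-yl)ethoxy in place of (2-nitro-1H-imidazol-1-yl)methyl gives a 1.3-fold higher number from compound 2 to compound 3 (0.11 log units; within the scatter) and so does not separate the two compounds. Going by these compounds alone, this is the first reading on the chain itself: on a saturated chain carbon, two bonds along the chain from an oxygen on an aromatic ring, the larger group with its added oxygen leaves the number within the scatter while the 3-bromophenyl stays fixed. No measurement at hand gives a reason for this result.

The compounds shown leave open whether a longer chain would also stay within the scatter, and whether an amine in place of the nitroimidazole would move the number beyond it. They also leave open whether the same chain change on the 3-chloro-4-fluorophenyl compound would give a similar step.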